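The compounds below may be only part of what the source reports. "The series", "measured", "known", "first", "only" and "open" are said of these compounds alone.

Compound 1 `CCCS(=O)(=O)N1CCC(CNC(=O)C2CC2)(C(=O)N2CCOCC2)CC1`: 0.3 h
Compound 2 `CCCS(=O)(=O)N1CCC(CNC(=O)c2ccc(F)cc2C(F)(F)F)(C(=O)N2CCOCC2)CC1`: 0.3 h

In an ADME assay on the whole organism for metabolic stability, with Rattus norvegicus as the target (on this read-out higher numbers stand for a longer-lived compound and lower numbers for a shorter-lived compound), compound 1 and compound 2 stand level, and compound 2 gives 0.3 h. Compound 3 `CCCS(=O)(=O)N1CCC(CNC(=O)c2ccccc2OC(F)(F)F)(C(=O)N2CCOCC2)CC1` carries 2-(trifluoromethoxy)phenyl in place of the 4-fluoro-2-(trifluoromethyl)phenyl of compound 2 on a carbonyl carbon: 2-(trifluoromethoxy)phenyl in place of 4-fluoro-2-(trifluoromethyl)phenyl on a carbonyl carbon. Among the compounds with values here, only one measured step bears on this place, no change at the digits printed from compound 1 to compound 2 (within the scatter), and it stayed within the scatter even with cyclopropyl as the group replaced. No shift beyond the scatter is therefore expected in this assay, and the expected step is no change at the digits printed from compound 2 to compound 3 (within the scatter). For compound 3 the estimate is 0.3 h, with an expected range of 0.15 h to 0.6 h.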

Compound 3, half-life: 0.3 h
Beside the measured number, compound 3's estimate shows no gap at the digits printed, within the range that was stated.
By their numbers in this assay, from the lowest: compounds 1, 2 and 3 (each within the scatter of the next).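

In this assay a second aryl group on this carbonyl carbon gives no change at the digits printed from compound 2 to compound 3 (within the scatter) and, set against cyclopropyl, no change at the digits printed from compound 1 to compound 3 (within the scatter) as well. The change from 4-fluoro-2-(trifluoromethyl)phenyl to 2-(trifluoromethoxy)phenyl brings in one hydrogen-bond acceptor, and all three groups at this place now stand level, aromatic or not. No supporting measurement is available to account for this flat result. From the compounds shown here alone, whether a carboxylic acid or an amine on this carbonyl carbon would move the number stays open, and so does whether changes elsewhere in the shared core would.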